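Closing the Amine into a Five-Membered Ring

The source may report more compounds than this note shows. Statements on the series, on what has been measured and on what is new or still open speak of the compounds shown alone.

Of the compounds shown here, three sharing one core have been tested, each differing only in the amine group on that core. Compound 1 `CCOc1c(NC)cnn(C)c1=O`, compound 2 `CCOc1c(N(C)C)cnn(C)c1=O` and compound 3 `CCOc1c(N2CCCCC2)cnn(C)c1=O` were run in a functional assay on the whole organism (strain Wistar) for inhibition, with Rattus norvegicus as the target, read by paw edema, with stated times of 30 min and 3 h, at a dose of 100 mg/kg by the oral route; on this read-out higher numbers stand for a stronger effect at the one dose given and lower numbers for a weaker effect; there compound 1 gives 31.1%, compound 2 gives 49.5% and compound 3 gives 14.1%. Compound 2 thus stands highest of the three numbers, with compound 1 nearest and compound 3 furthest.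

The unmeasured compound 4 `CCOc1c(N2CCCC2)cnn(C)c1=O` differs from compound 2 in one place: pyrrolidin-1-yl in place of dimethylamino on an aromatic carbon. Among the compounds with values here, only one measured step touches this position, namely a number 18.4 percentage points higher from compound 1 to compound 2 (beyond the scatter), showing that a small change at the amine can move the read-out beyond the scatter. Compound 3, which carries a larger ring at the same carbon, gives the lowest number of the three. Since pyrrolidin-1-yl adds heavy atoms and a ring in the same direction, a downward step beyond the scatter is expected, though smaller than the distance from compound 2 to compound 3. Compound 4 is estimated at 30%, within an expected range from 12% to 48%. The expected step is a number 19.5 percentage points lower from compound 2 to compound 4 (beyond the scatter).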

Compound 4, a percentage reported as inhibition, in the whole organism at one dose (the size of the read-out at that dose, not a potency): 23%
Beside the measured number, compound 4's estimate is 7 percentage points above it, within the range that was stated.
By their numbers in this assay, from the lowest: compounds 3, 4 and 1 (each within the scatter of the next, the first and the last beyond it); then compound 2.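

Tying the two methyl groups of dimethylamino into the pyrrolidin-1-yl ring does not preserve the effect at this carbon (a number 26.5 percentage points lower from compound 2 to compound 4 (beyond the scatter)), although the counts of hydrogen-bond donors and acceptors stay the same. The same ring cannot be told apart from the methylamino group of the core (a number 8.1 percentage points lower from compound 1 to compound 4 (within the scatter)), so compound 2 now stands alone above both ring compounds, while compound 1, which has no ring, also lies below it and shows that the absence of a ring is not enough for the highest number. Nothing available here bears on the reason for this drop.

Still open, going by these compounds, is whether an open chain slightly larger than dimethylamino, such as diethylamino, keeps the number of compound 2. A ring with a second hetero atom, such as morpholin-4-yl, also remains to be placed among these amines.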